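The compounds below may be only part of what the source reports. "The series", "measured", "known", "first", "only" and "open" are said of these compounds alone.

For the measured compounds named here, compound 2 `CCOc1ccc(COc2ccccc2OCCNCCOc2c(OC)cccc2OC)cc1` stands highest of the two numbers so far: in a functional assay on spleen for antagonist activity at Alpha-1B adrenergic receptor (Rattus norvegicus) (a higher number here means a more potent compound, by a factor of ten per unit of this negative logarithm, a lower number a less potent compound), compound 2 gives 8.23, while compound 1 `COc1cccc(OC)c1OCCNCCOc1ccccc1OCc1ccccc1C` gives 7.67, and the step of a number 0.56 log units higher from compound 1 to compound 2 (beyond the scatter) lies beyond the scatter. Compound 3 `COc1cccc(OC)c1OCCNCCOc1ccccc1OCc1ccc(OC(C)C)cc1` differs from compound 2 by methyl in place of hydrogen on a saturated chain carbon bound to an oxygen on an aromatic ring and a saturated chain carbon, which reads ethoxy to isopropoxy. Going by the values given here, the one measured step replaced the whole aryl group rather than growing ethyl to isopropyl, so it bears only loosely on this change, and no step beyond the scatter is expected. Compound 3 is therefore expected to give about 8.2 in this assay, between 7.7 and 8.7. The expected step is a number 0.03 log units lower from compound 2 to compound 3 (within the scatter).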

Compound 3, negative logarithm of the antagonist equilibrium constant: 8.62
Compound 3: middle estimate off by 0.42 log units, on the low side; measured number inside the range.
By their numbers in this assay, from the lowest: compound 1; then compound 2; then compound 3.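

In this assay, a single added methyl, which turns ethoxy into isopropoxy, gives a number 0.39 log units higher from compound 2 to compound 3 (beyond the scatter), so a change as small as ethyl to isopropyl still moves the number at this place, which the earlier exchange of the whole aryl group could not show. With 4-isopropoxyphenyl in place of 2-methylphenyl, the gain widens to a number 0.95 log units higher from compound 1 to compound 3 (beyond the scatter). Nothing available explains why this methyl raises the number. As far as these compounds go, whether a longer chain such as butoxy, or a ring such as cyclopentyloxy, would raise the number further or lower it stays open.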